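A Methyl Group Added Where Methyl Once Replaced Hydrogen

The source may report more compounds than this note shows. Statements on the series, on what has been measured and on what is new or still open speak of the compounds shown alone.

Of the compounds shown here, three have been measured in a functional assay on the whole organism for antagonist activity, with Rattus norvegicus as the target; a higher number here means that more compound is needed for the effect, a lower number that less compound is needed. Compound 1 `CCCn1cnc2c(NC3CC3)ncnc21` gives 6 mg/kg. Compound 2 `CC(C)Cn1cnc2c(NC3CC3)ncnc21` gives 10 mg/kg. Compound 3 `CNc1nc(NC2CC2)c2ncn(CC3CC3)c2n1` gives 3 mg/kg, the lowest of the three numbers, though its gap to compound 1 stays within the scatter; only its gap to compound 2 lies beyond it.

Compound 1 and compound 2 differ in a single place, (methyl in place of hydrogen on a saturated chain carbon bound to two saturated chain carbons), and the change brought a 1.7-fold higher number from compound 1 to compound 2 (0.22 log units; within the scatter), a step that means nothing against the usual scatter. Compound 3 shares a core with neither of them in a simple way: the difference between the two cores is not broken down here.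

Compound 4 `CCNc1nc(NC2CC2)c2ncn(CC3CC3)c2n1` is not yet measured. It differs from compound 3 by methyl in place of hydrogen on a saturated chain carbon bound to a nitrogen on an aromatic ring. For the measured compounds named here, this is the same kind of change as the one from compound 1 to compound 2, not the same: there the place was on a saturated chain carbon bound to two saturated chain carbons, here it is on a saturated chain carbon bound to a nitrogen on an aromatic ring.

Because the earlier step of this kind was a 1.7-fold higher number from compound 1 to compound 2 (0.22 log units; within the scatter), the author expects the step from compound 3 to compound 4 in this assay to be about as small, estimated as a 1.3-fold higher number from compound 3 to compound 4 (0.12 log units; within the scatter). The estimate for compound 4 is therefore 4 mg/kg, expected to fall between 2 mg/kg and 9 mg/kg.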

Compound 4, dose for half-maximal effect: 9 mg/kg
Compound 4: the middle estimate sits 2.3-fold (0.35 log units) below what was measured; the range from low to high includes it.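

In this assay, methyl in place of hydrogen on a saturated chain carbon bound to a nitrogen on an aromatic ring gave a 3.0-fold higher number from compound 3 to compound 4 (0.48 log units; beyond the scatter), so on this core the change turns methylamino into ethylamino with a shift that can be told apart from repeated-measurement noise. Set beside the earlier step, which stayed within the scatter, this one cannot be called different, and the two are compatible with a single effect of the change on both cores: the same change on two cores in this assay, a 1.7-fold higher number (0.22 log units; within the scatter) from compound 1 to compound 2 and a 3.0-fold higher number (0.48 log units; beyond the scatter) from compound 3 to compound 4, 1.8-fold (0.26 log units) apart, within the scatter of two such steps. For the compounds shown here, this does not show that the change carries over with a fixed size, since there are only two pairs, the methyl enters at a different kind of carbon in each, and one step alone passes the scatter, so the pairs neither establish a rule for the series nor give any reason for the shift.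

The compounds shown leave open whether the trend continues with a longer chain such as propylamino in place of ethylamino, or how a plain amino group would compare with methylamino on the core of compound 3. They also leave open how a branched chain, a hydroxyl or an amine at the end of that group would read in this assay.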